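The source may hold more compounds than are shown below. What is called first, only, known or untested is meant among the compounds shown, and "the series" means these compounds.

Compound 1 `COc1cc(C(=O)c2sc(-c3ccc([N+](=O)[O-])cc3)cc2N)cc(OC)c1OC` gives 110 nM in a functional assay on MOLT-4 cells (Homo sapiens) for antiproliferative activity (on this read-out lower numbers stand for stronger inhibition and higher numbers for weaker inhibition), the lowest of the two numbers measured. Compound 2 `COc1cc(C(=O)c2sc(-c3ccc(I)cc3)cc2N)cc(OC)c1OC` gives 190 nM in this assay, a step of a 1.7-fold higher number from compound 1 to compound 2 (0.24 log units; within the scatter). Compound 3 `COc1cc(C(=O)c2sc(-c3ccsc3)cc2N)cc(OC)c1OC` differs from compound 1 in one place: thiophen-3-yl in place of 4-nitrophenyl on an aromatic carbon. Within the data shown here, the only measured step, a 1.7-fold higher number from compound 1 to compound 2 (0.24 log units; within the scatter), exchanges one group on the same aromatic carbon and stays within the scatter, so a step of similar size is expected here, though no measured pair tests a thiophen-3-yl directly. Compound 3 is therefore estimated at 250 nM, with a range from 80 nM to 800 nM, an expected step of a 2.3-fold higher number from compound 1 to compound 3 (0.36 log units; beyond the scatter).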

Compound 3, half-maximal inhibitory concentration: 8.8 nM
For compound 3 the middle estimate is 28-fold (1.45 log units) above the measured one; measured number outside the range, below it.
By their numbers in this assay, from the lowest: compound 3; then compounds 1 and 2 (each within the scatter of the next).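

The number at this position can move strongly after all: the nitro-to-iodo exchange on the phenyl ring stayed within the scatter, but replacing the whole ring with thiophen-3-yl gives a 13-fold lower number from compound 1 to compound 3 (1.10 log units; beyond the scatter) and also a 22-fold lower number from compound 2 to compound 3 (1.33 log units; beyond the scatter) at the same carbon. So changing the ring itself matters here far more than changing the group that the phenyl ring carries. Nothing measured here accounts for this drop. Open, from the compounds shown here alone, is whether the ring sulfur or the five-membered ring carries the gain. A furan-3-yl or an unsubstituted phenyl on this carbon would help separate the two.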